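This account rests on a few compounds, and the source may have more. Where it says the series, first, only, none or still open, it means among the compounds named here.

Working notes on the series. In a functional assay on MIA PaCa-2 cells (Homo sapiens) for cytotoxicity, read by MTT assay, with a stated time of 72 h (on this read-out higher numbers stand for weaker inhibition and lower numbers for stronger inhibition), compound 1 `CCc1ccc(-c2ccc(NC3=CC(=O)c4ncncc4C3=O)cc2)cc1` gives 2000 nM and compound 2 `Cc1ccc(-c2ccc(NC3=CC(=O)c4ncncc4C3=O)cc2F)cc1` gives 4600 nM; compound 1 thus has the lower of the two numbers, and the gap to compound 2 lies beyond the scatter. Compound 3 `NC(=O)c1ccc(NC2=CC(=O)c3ncncc3C2=O)cc1` is not yet measured in this assay. It differs from compound 1 by carbamoyl in place of 4-ethylphenyl on an aromatic carbon. Going by the values given here, no measured pair shows this change, so the size of the step can only be expected. The step from compound 1 to compound 3 in this assay is expected to be a 4.0-fold higher number from compound 1 to compound 3 (0.60 log units; beyond the scatter), that is a clearly weaker result beyond the scatter. Compound 3 is therefore estimated at 8000 nM, with a range of 2500 nM to 25000 nM.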

Compound 3, half-maximal inhibitory concentration: 8000 nM
Estimate against measurement, compound 3: no gap at the digits printed; the range from low to high includes it.
By their numbers in this assay, from the lowest: compound 1; then compounds 2 and 3 (each within the scatter of the next).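

Going by these compounds alone, at the position on an aromatic carbon para to a large group, carbamoyl in place of 4-ethylphenyl gives a 4.0-fold higher number from compound 1 to compound 3 (0.60 log units; beyond the scatter) in this assay, the first step between compounds differing in one place. The step is modest for so large a change: an aromatic ring leaves, and compound 3 still gives a measured 8000 nM. Nothing measured here accounts for the step.

On these data alone, it remains open whether the step follows the loss of the ring or the entry of carbamoyl. Phenyl, ethyl, an amine or a carboxylic acid at this position would separate the two.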